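Side-chain variation and buffer solubility in one series

This account rests on a few compounds, and the source may have more. Where it says the series, first, only, none or still open, it means among the compounds named here.

Measured compounds:
Compound 1, `CS(=O)(=O)c1nn(Cc2nc3cc(Cl)ccc3n2CCCO)c2cnccc12`, gives 40 ug/mL in a physicochemical assay for solubility, read by spectrophotometry, in phosphate buffer, at pH 6.5; a lower number here means a less soluble compound, a higher number a more soluble compound.
Compound 2, `CS(=O)(=O)c1nn(Cc2nc3cc(Cl)ccc3n2CCCCO)c2cnccc12`, gives 147 ug/mL in this assay.
Compound 3, `CS(=O)(=O)c1nn(Cc2nc3cc(Cl)ccc3n2CCOCCO)c2cnccc12`, gives 181 ug/mL in this assay.

Compound 3 holds the highest number of the three. Its gap to compound 1 is clear: a 4.5-fold higher number from compound 1 to compound 3 (0.66 log units; beyond the scatter). Its gap to compound 2 is not: a 1.2-fold higher number from compound 2 to compound 3 (0.09 log units; within the scatter). The other measured step, a 3.7-fold higher number from compound 1 to compound 2 (0.57 log units; beyond the scatter), runs in the same direction as the first.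

The next compound, compound 4, is `CS(=O)(=O)c1nn(Cc2nc3cc(Cl)ccc3n2CCC(F)(F)F)c2cnccc12`. The change from compound 3 is trifluoromethyl in place of 2-hydroxyethoxy on a saturated chain carbon, two bonds along the chain from an aromatic nitrogen. All three measured steps keep a hydrogen-bond donor on the chain and shift only its distance or the atoms between it and the aromatic nitrogen; none of them removes the donor and both acceptors, as this change does. The measured steps therefore bear on it only loosely: they show that the shortest hydroxy chain of compound 1 sits well below compound 3, and that the longer chains of compound 2 and compound 3 are indistinguishable. With the donor and acceptors gone, the expected step is downward and beyond the scatter, estimated as a 15-fold lower number from compound 3 to compound 4 (1.18 log units; beyond the scatter). Compound 4 is therefore expected at about 12 ug/mL in this assay, with a range of 3 ug/mL to 45 ug/mL.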

Compound 4, solubility: 3 ug/mL
For compound 4 the middle estimate is 4.0-fold (0.60 log units) above the measured one; low and high end bracket the measured number.
By their numbers in this assay, from the lowest: compound 4; then compound 1; then compounds 2 and 3 (each within the scatter of the next).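

In this assay trifluoromethyl on a saturated chain carbon, two bonds along the chain from an aromatic nitrogen, gives a large downward step against each hydroxy-bearing chain (first a 60-fold lower number from compound 3 to compound 4 (1.78 log units; beyond the scatter); then a 49-fold lower number from compound 2 to compound 4 (1.69 log units; beyond the scatter); and last a 13-fold lower number from compound 1 to compound 4 (1.12 log units; beyond the scatter)). The earlier steps shown here showed only how far the number moves while the chain keeps its hydroxy group; this change, in which a group with 0 hydrogen-bond donors and 0 hydrogen-bond acceptors enters, shows that the same position can carry the number well below even compound 1, so the shared core does not by itself fix the read-out. Nothing measured on these compounds gives a reason for the size of these steps.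

The compounds shown leave open whether the low number of compound 4 goes with the loss of the hydroxy group or with the entry of the fluorines, a question that a plain propyl chain or a methoxyethyl chain at the same position would separate. They also leave open whether an amine or a carboxylic acid on this chain would stand above compound 3, or only level with it, in this assay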